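A few compounds are considered here, and "the series" means these few. Any claim that something is new, unique, unknown or untested is made for them only; others in the source may bear on it.

Measured so far in an ADME assay on a cell-free system (plasma, Homo sapiens) for metabolic stability, with Plasma (Rattus norvegicus) as the target, read by HPLC, at pH 7.4; on this read-out higher numbers stand for a longer-lived compound and lower numbers for a shorter-lived compound:

- compound 1 `CC(=O)Oc1ccccc1C(=O)O[C@H]1CO[C@H]2[C@@H]1OC[C@H]2O` gives 0.0183 h
- compound 2 `CC(=O)Oc1ccccc1C(=O)O[C@H]1CO[C@H]2[C@@H]1OC[C@H]2OC(=O)c1ccnn1C` gives 0.0642 h
- compound 3 `CC(=O)Oc1ccccc1C(=O)O[C@H]1CO[C@H]2[C@@H]1OC[C@H]2OC(C)=O` gives 0.0095 h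

Compound 2 holds the highest number of the three. Its nearest neighbour is compound 1, a 3.5-fold higher number from compound 1 to compound 2 (0.55 log units; beyond the scatter); its furthest is compound 3, a 6.8-fold lower number from compound 2 to compound 3 (0.83 log units; beyond the scatter). Between the two lower compounds the step is a 1.9-fold lower number from compound 1 to compound 3 (0.28 log units; within the scatter).

Compound 4 `CCC(=O)O[C@@H]1CO[C@H]2[C@@H]1OC[C@@H]2OC(=O)c1ccccc1OC(C)=O` is not yet measured. It differs from compound 2 as follows: ethyl in place of 1-methyl-1H-pyrazol-5-yl on a carbonyl carbon. Going by the values given here, the only measured step that bears on this change is the one from compound 2 to compound 3, where the same 1-methyl-1H-pyrazol-5-yl was replaced on the same carbonyl carbon, by methyl instead of ethyl, and the number fell: a 6.8-fold lower number from compound 2 to compound 3 (0.83 log units; beyond the scatter). Compound 3 and compound 4 both carry a short alkyl on that carbonyl carbon, so compound 4 is expected to come out near compound 3, a downward step beyond the scatter, a 5.4-fold lower number from compound 2 to compound 4 (0.73 log units; beyond the scatter). The estimate for compound 4 in this assay is 0.012 h, with a range from 0.005 h to 0.03 h.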

Compound 4, half-life: 0.011 h
Compound 4: the middle estimate sits 1.1-fold (0.04 log units) above what was measured; low and high end bracket the measured number.
By their numbers in this assay, from the lowest: compounds 3, 4 and 1 (each within the scatter of the next); then compound 2.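

In this assay the propanoyl ester behaves like the acetyl ester (a 1.2-fold higher number from compound 3 to compound 4 (0.06 log units; within the scatter)), so the added methyl on the saturated chain carbon bound to a carbonyl carbon shows no effect. Swapping the 1-methyl-1H-pyrazol-5-yl for a second short alkyl, ethyl, also gives a drop beyond the scatter (a 5.8-fold lower number from compound 2 to compound 4 (0.77 log units; beyond the scatter)), so that drop no longer rests on methyl alone. Propanoyl in place of hydrogen on the oxygen stays within the scatter (a 1.7-fold lower number from compound 1 to compound 4 (0.22 log units; within the scatter)), as acetyl did, leaving (1-methyl-1H-pyrazol-5-yl)carbonyl as the only group shown at this position that moves the number beyond the scatter.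

Open, from the compounds shown here alone, is whether a longer chain such as butanoyl, or a benzoyl, would hold the number of the short alkyl esters or that of compound 2. The data shown offer no measurement that accounts for the gap between the pyrazole ester and the alkyl esters.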